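The source may hold more compounds than are shown below. What is called first, only, known or untested is meant among the compounds shown, and "the series" means these compounds.

Compound 1 `CC(C)=CCC/C(C)=C/CC/C(C)=C/C(=O)NC(=N)N` is the shorter of the two measured compounds, with a hydrogen on an amine nitrogen of the shared core. In a functional assay on MCF7 cells (Homo sapiens) for inhibition, read by MTT assay, with a stated time of 72 h (a higher number here means a weaker inhibitor of growth, a lower number a stronger inhibitor of growth), compound 1 gives 22000 nM. Compound 2 `CC(C)=CCC/C(C)=C/CC/C(C)=C/C(=O)NC(=N)NC(=O)C=C(C)C` carries a (2-methylprop-1-en-1-yl)carbonyl in place of that hydrogen on an amine nitrogen, and in this assay compound 2 gives 23400 nM. The step of a 1.1-fold higher number from compound 1 to compound 2 (0.03 log units; within the scatter) shows that adding this group left the read-out essentially unchanged. Among the two measured numbers compound 2 holds the highest, and its only neighbour, compound 1, lies within the scatter of it, so the two cannot be told apart.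

Compound 3 `CC(C)=CCC/C(C)=C/CC/C(C)=C/C(=O)NC(=N)NC(=O)/C=C(\C)CC/C=C(\C)CCC=C(C)C` grows out of compound 2 by one change: 3,7-dimethylocta-2,6-dien-1-yl in place of hydrogen on a saturated chain carbon bound to a double-bonded chain carbon. For the measured compounds named here, the only measured step that bears on this is the one from compound 1 to compound 2, which also added carbon atoms to the molecule and stayed within the scatter. Adding a 3,7-dimethylocta-2,6-dien-1-yl therefore gives no basis to expect a step beyond the scatter in either direction in this assay. For compound 3 the expected step is a 1.1-fold higher number from compound 2 to compound 3 (0.03 log units; within the scatter). Compound 3 is accordingly estimated at 25000 nM, with a range from 10000 nM to 60000 nM.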

Compound 3, concentration for 50% growth inhibition: 30300 nM
Beside the measured number, compound 3's estimate is 1.2-fold (0.08 log units) below it, and the stated range covers the measured number.
By their numbers in this assay, from the lowest: compounds 1, 2 and 3 (each within the scatter of the next).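

In this assay, the step of a 1.3-fold higher number from compound 2 to compound 3 (0.11 log units; within the scatter) shows that this much larger change also gives a number that cannot be told apart from that of compound 2. The earlier compounds shown here showed only what happens when a (2-methylprop-1-en-1-yl)carbonyl replaces a hydrogen on an amine nitrogen. This result adds a second position, a saturated chain carbon bound to a double-bonded chain carbon, where a 3,7-dimethylocta-2,6-dien-1-yl of 10 heavy atoms, with 2 double bonds outside aromatic rings, leaves the read-out within the scatter, and no supporting measurement is available to explain this finding.

The compounds shown leave open whether an amine or a carboxylic acid on this same saturated chain carbon would give a step beyond the scatter, since only a hydrogen and one hydrocarbon chain have been compared there. They also leave open whether a phenyl ring or a much longer chain at this carbon would separate from compound 2, so no trend with chain size can be drawn from these few closely spaced numbers.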